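Urea series: removal of one trifluoromethyl from compound 3

This account rests on a few compounds, and the source may have more. Where it says the series, first, only, none or still open, it means among the compounds named here.

Compound 1 `O=C(Nc1cccc(-n2cc(-c3ccncc3)c(-c3cc(O)cc(Cl)c3)n2)c1)Nc1ccc(Cl)c(C(F)(F)F)c1` gives 100% in a functional assay on A549 cells (Homo sapiens) for inhibition, read by sulforhodamine B assay, with a stated time of 48 h, tested at 0.1 uM; a higher number here means a weaker effect of the compound at the concentration tested, a lower number a stronger effect. Compound 2 `O=C(Nc1cccc(-n2cc(-c3ccncc3)c(-c3cc(O)cc(Cl)c3)n2)c1)Nc1ccc(Cl)c(Cl)c1` gives 99%; the step of a number 1 percentage points lower from compound 1 to compound 2 (within the scatter). Compound 3 `COc1cc(Cl)cc(-c2nn(-c3cccc(NC(=O)Nc4cc(C(F)(F)F)cc(C(F)(F)F)c4)c3)cc2-c2ccncc2)c1` gives 95%, with compound 1 and compound 2 both within the scatter of it, so the three numbers are not separated.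

Compound 4 `COc1cc(Cl)cc(-c2nn(-c3cccc(NC(=O)Nc4cccc(C(F)(F)F)c4)c3)cc2-c2ccncc2)c1` differs from compound 3 in one place: hydrogen in place of trifluoromethyl on an aromatic carbon. Among the compounds with values here, the only measured step on that aryl ring exchanges a trifluoromethyl and stays within the scatter, and no step in this set moves the read-out beyond it, so no change beyond the scatter is expected here either. For compound 4 the expected step is a number 2 percentage points higher from compound 3 to compound 4 (within the scatter), giving an estimate of 97% with a range from 88% to 105%.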

Compound 4, a percentage reported as activity, at one concentration (the size of the read-out at that concentration, not a potency): 96%
Estimate against measurement, compound 4: 1 percentage points above, and the stated range covers the measured number.
By their numbers in this assay, from the lowest: compounds 3, 4, 2 and 1 (each within the scatter of the next).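

In this assay hydrogen in place of trifluoromethyl gives a number 1 percentage points higher from compound 3 to compound 4 (within the scatter) and so extends the earlier picture: at this position on the aryl ring of the urea, outright loss of the group, not only its exchange, leaves the read-out unseparated. With one trifluoromethyl left on that ring, compound 4 is not separated from compound 3 at this single concentration. No evidence bearing on this result is available.

From the compounds shown here alone, whether an amine or a carboxylic acid at this place would move the read-out beyond the scatter remains open. Also open, going by these compounds, is whether removing the remaining trifluoromethyl would do so.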